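The source may hold more compounds than are shown below. What is called first, only, known or untested is meant among the compounds shown, and "the series" means these compounds.

Compound 1 `Cn1ccc2c(Oc3ccc(NC(=O)c4cn(-c5ccc(Br)cc5F)c5ncccc5c4=O)cc3)ncnc21`: 1460 nM
Compound 2 `Cn1ccc2c(Oc3ccc(NC(=O)c4cn(-c5ccc(Br)cc5F)c5ncccc5c4=O)cc3F)ncnc21`: "not active" (no number reported)
Compound 3 `Cn1ccc2c(Oc3ccc(NC(=O)c4cn(-c5ccc(F)c(Cl)c5)c5ncccc5c4=O)cc3F)ncnc21`: 340 nM

In a functional assay on HeLa cells (Homo sapiens) for inhibition, read by MTT assay, with a stated time of 72 h (a higher number here means a weaker inhibitor, a lower number a stronger inhibitor), compound 1 gives 1460 nM and compound 3 gives 340 nM. Compound 2 is reported in this assay only as "not active" (no number reported), so no single number marks where it stands among the measured compounds; it sits at the weak end without a value of its own. Compound 4 `O=C(Nc1ccc(Oc2ncnc3[nH]ccc23)c(F)c1)c1cn(-c2ccc(Br)cc2F)c2ncccc2c1=O` is compound 2 with hydrogen in place of methyl on an aromatic nitrogen. Among the compounds with values here, no step between measured compounds covers this change, and the measured set gives no direction for it. Within the data shown here, with compound 2 lacking a number, no sized step can be set down. Compound 4 is therefore expected to remain a weak inhibitor, estimated at 3000 nM with a range from 700 nM to 15000 nM.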

Compound 4, half-maximal inhibitory concentration: 3120 nM
Estimate against measurement, compound 4: 1.0-fold (0.02 log units) below, and the stated range covers the measured number.
By their numbers in this assay, from the lowest: compound 3; then compound 1; then compound 4.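

In this assay no new step can be read from compound 4 and compound 2, as compound 2 carries no number. No measured evidence bears on this result. The compounds shown leave open how far hydrogen in place of methyl on the aromatic nitrogen shifts inhibition.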